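The source may hold more compounds than are shown below. What is called first, only, known or untested is meant among the compounds shown, and "the series" means these compounds.

In an ADME assay on BJ cells (Homo sapiens) for cytotoxicity, with a stated time of 72 h (on this read-out higher numbers stand for an effect only at larger amounts of compound and lower numbers for an effect already at smaller amounts), compound 1 `CCc1ccc(-c2nc3c(c(C)nn3-c3ccccc3)c(-c3ccccc3O)c2C#N)cc1` gives > 20000 nM as a limit of the assay and not a number. Compound 2 `CCc1ccc(-c2nc3c(c(C)nn3-c3ccccc3)c(-c3ccccc3OC)c2C#N)cc1` gives > 20000 nM in this assay as a limit as well. Compound 3 `CCc1ccc(-c2nc3c(c(C)nn3-c3ccccc3)c(-c3ccccc3C(=O)OC)c2C#N)cc1` gives > 20000 nM in this assay and this too is a limit. Compound 1 therefore stands at the limit of > 20000 nM in this assay, at which 3 of the 3 values shown sit, and has no number of its own.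

Compound 4 `Cc1ccc(-c2nc3c(c(C)nn3-c3ccccc3)c(-c3ccccc3O)c2C#N)cc1` differs from compound 1 by hydrogen in place of methyl on a saturated chain carbon bound to an aromatic carbon in a single place, hydrogen in place of methyl on a saturated chain carbon bound to an aromatic carbon, which turns 4-ethylphenyl into 4-methylphenyl.

The measured steps bear on this only loosely. They are a step that the two limits leave unreadable from compound 1 to compound 2 and a step that the two limits leave unreadable from compound 1 to compound 3 and also a step that the two limits leave unreadable from compound 2 to compound 3 in this assay and all three leave the ethyl group untouched. For the measured compounds named here, none has a readable size, so no size carries over, and no measured pair shows the change at hand.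

What is expected in this assay is a step that the limit leaves unreadable from compound 1 to compound 4 with no direction and nothing beyond the scatter, most likely another limit. For compound 4 the estimated value is 25000 nM within an expected range from 12000 nM to 50000 nM in this assay and no tighter claim is made.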

Compound 4, half-maximal effective concentration: 22200 nM
Compound 4: middle estimate off by 1.1-fold (0.05 log units), on the high side, within the range that was stated.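

No step can be read between compound 1 and compound 4 in this assay, so the change from 4-ethylphenyl to 4-methylphenyl has no readable size. Compounds 1, 2 and 3 stand at: the limit of > 20000 nM in this assay, at which 3 of the 4 values shown sit.

The compounds shown leave open the size of any single change in this assay, with no pair here carrying two numbers.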